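A few compounds are considered here, and "the series" means these few. Any claim that something is new, unique, unknown or untested is made for them only; others in the source may bear on it.

Values in a functional assay on LoVo cells (Homo sapiens) for antiproliferative activity, read by MTT assay, with a stated time of 72 h; on this read-out higher numbers stand for weaker inhibition and lower numbers for stronger inhibition:
- compound 1 `CN1CCC(NC(=O)c2ccc(Cn3nc(-c4cnn(C)c4)c4ccccc4c3=O)cc2)CC1`: 83300 nM
- compound 2 `Cc1noc(C)c1-c1nn(Cc2ccc(C(=O)NC3CC(C)(C)N([O])C(C)(C)C3)cc2)c(=O)c2ccccc12`: 41200 nM

Compound 2 stands lowest of the two numbers at 41200 nM, and the gap to compound 1 at 83300 nM lies beyond the scatter. Compound 3 `Cc1noc(C)c1-c1nn(Cc2ccc(C(=O)NC3CCN(C)CC3)cc2)c(=O)c2ccccc12` departs from compound 2 as follows: a group of 7 heavy atoms (6 carbon, 1 nitrogen; one six-membered non-aromatic ring with 1 hetero atom) in place of a group of 11 heavy atoms (9 carbon, 1 nitrogen, 1 oxygen; one six-membered non-aromatic ring with 1 hetero atom), on an amide-type nitrogen. Going by the values given here, no measured step covers this change, so the expectation is weak. A modest rise in this assay is expected, meaning weaker inhibition, though a result within the scatter remains possible. The expected size is a 1.5-fold higher number from compound 2 to compound 3 (0.16 log units; within the scatter). Compound 3 is estimated at 60000 nM (range 25000 nM to 130000 nM).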

Compound 3, half-maximal inhibitory concentration: > 100000 nM
Compound 3 gave a limit, no number; the forecaster's own chance of this, stated with the estimate: 15%; middle value at least 1.6-fold (0.22 log units) away from the limit.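

In this assay, going by these compounds alone, the 1-methylpiperidin-4-yl group on the amide-type nitrogen reads as weaker than the group it replaces in compound 2, giving the first step at this position: an at least 2.4-fold higher number from compound 2 to compound 3 (0.38 log units; beyond the scatter). The change on the aromatic carbon, 3,5-dimethyl-1,2-oxazol-4-yl in place of 1-methyl-1H-pyrazol-4-yl, reads only as an at least 1.2-fold higher number from compound 1 to compound 3 (0.07 log units; that floor lies within the scatter) and so sets no firm order. The value of compound 3 is a limit, not a number: the limit of > 100000 nM in this assay, at which 1 of the 3 values shown sits.

On these data alone, how far compound 3 lies past its limit stays open. So does how a primary amine or a carboxylic acid on the amide-type nitrogen would read.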